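This account rests on a few compounds, and the source may have more. Where it says the series, first, only, none or still open, it means among the compounds named here.

Measured compounds:
compound 1 `O=C(NCCCNc1nc(Nc2cccc(F)c2)ncc1Br)C1CCC1` — an assay on isolated protein for inhibition of serine/threonine-protein kinase TBK1 (Homo sapiens); on this read-out higher numbers stand for weaker inhibition and lower numbers for stronger inhibition: 2 nM
compound 2 `O=C(NCCCNc1nc(Nc2cccc(F)c2)ncc1C1CC1)C1CCC1` — this assay: 8 nM
compound 3 `CCc1cnc(Nc2cccc(F)c2)nc1NCCCNC(=O)C1CCC1` — this assay: 63 nM

Compound 1 gives the lowest number of the three. Its nearest neighbour is compound 2, a 4.0-fold higher number from compound 1 to compound 2 (0.60 log units; beyond the scatter); the furthest is compound 3, a 32-fold higher number from compound 1 to compound 3 (1.50 log units; beyond the scatter). Between the two others the step is a 7.9-fold higher number from compound 2 to compound 3 (0.90 log units; beyond the scatter). All three measured steps change the group on an aromatic carbon of the shared core; the amide end of the chain is the same throughout.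

Compound 4 `COCCC(=O)NCCCNc1nc(Nc2cccc(F)c2)ncc1Br` differs from compound 1 at that amide end: 2-methoxyethyl in place of cyclobutyl on a carbonyl carbon. Among the compounds with values here, no measured step touches the carbonyl side, so none of the three steps bears directly on this change; what is known is only that the bromo of compound 1, the group behind the lowest number, is kept. With nothing on the new position, the expectation is a step near the scatter, if anything towards a higher number, a 2.5-fold higher number from compound 1 to compound 4 (0.40 log units; beyond the scatter). For compound 4 in this assay the estimate is 5 nM, in the range 1.5 nM to 20 nM.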

Compound 4, half-maximal inhibitory concentration: 60 nM
Compound 4: middle estimate off by 12-fold (1.08 log units), on the low side; measured number outside the range, above it.
By their numbers in this assay, from the lowest: compound 1; then compound 2; then compounds 4 and 3 (each within the scatter of the next).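

The amide end is not a silent position: in this assay, with the bromo kept, 2-methoxyethyl in place of cyclobutyl on the carbonyl carbon gives a 30-fold higher number from compound 1 to compound 4 (1.48 log units; beyond the scatter), so the cyclobutyl group matters to the low number of compound 1. A change at this carbonyl carbon can therefore weigh as much as the largest change seen on the aromatic carbon, a 32-fold higher number from compound 1 to compound 3 (1.50 log units; beyond the scatter), and compounds 4 and 3 stand within the scatter of each other. No measurement at hand accounts for the step at the amide end.

This change removes a four-membered ring and brings in an oxygen at once, so the compounds shown do not separate the two; a plain butyl chain or an oxetanyl ring on the carbonyl carbon would bear on that. Going by these compounds, whether the step keeps its size with cyclopropyl or ethyl in place of bromo also remains open.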